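The source may report more compounds than this note shows. Statements on the series, on what has been measured and on what is new or still open speak of the compounds shown alone.

Compound 3 `O=C(Nc1cccc(-c2nc3ccccc3s2)c1)c1cc([N+](=O)[O-])ccc1Cl` is the reference for this step. In an ADME assay on BJ cells (Homo sapiens) for cytotoxicity, with a stated time of 72 h (a lower number here means that less compound is needed, a higher number that more compound is needed for the effect), compound 3 gives only a limit, > 27000 nM. Compound 1 `COc1ccc(-c2nc3ccccc3s2)cc1NC(=O)c1cc([N+](=O)[O-])ccc1Cl` in this assay likewise gives only a limit, > 25000 nM. Compound 2 `O=C(Nc1cccc(-c2nc3ccccc3s2)c1)c1cc([N+](=O)[O-])c(O)cc1Cl` also gives only a limit, > 25000 nM. All three values shown are thus limits, summarised by the limit of > 25000 nM in this assay, at which 2 of the 3 values shown sit, and (the limit of > 27000 nM in this assay, at which 1 of the 3 values shown sits); compound 3 stands at one of them, with no readable number. The change to compound 4 `COc1ccc(NC(=O)c2cc([N+](=O)[O-])ccc2Cl)cc1-c1nc2ccccc2s1` is methoxy in place of hydrogen on an aromatic carbon. The measured steps a step that the two limits leave unreadable from compound 1 to compound 3 and a step that the two limits leave unreadable from compound 2 to compound 3 bear on it, but their size is not readable from the limits. For compound 4 no step beyond the scatter is therefore expected, and a step that the limit leaves unreadable from compound 3 to compound 4 is the expected step. Compound 4 is estimated at 40000 nM, between 20000 nM and 100000 nM, most probably reported again only as a limit.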

Compound 4, half-maximal effective concentration: > 25000 nM
Compound 4 ended at the assay's limit; the forecaster's own chance of this, stated with the estimate: 85%; the middle value is on the limit's open side.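

Within the data shown here, compound 3 and compound 4 both give only limits in this assay, so no step between them can be read. The compounds shown leave open whether methoxy in place of hydrogen shifts the half-maximal effective concentration at all.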